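Fluoro in Place of Hydrogen Across Two Cores

The source may hold more compounds than are shown below. What is called first, only, known or untested is meant among the compounds shown, and "the series" means these compounds.

Of the compounds shown here, three have been measured in a functional assay on MKN-45 cells (Homo sapiens) for cytotoxicity, read by MTT assay, with a stated time of 72 h; a higher number here means a weaker inhibitor, a lower number a stronger inhibitor. Compound 1 `COc1cc2c(Oc3ccc(NC(=O)c4cc(-c5ccccc5)ccn4)cc3F)ccnc2cc1OCCCN1CCCC1` gives 210 nM there. Compound 2 `COc1cc2c(Oc3ccc(NC(=O)c4cc(-c5ccc(F)cc5)ccn4)cc3F)ccnc2cc1OCCCN1CCCC1` differs from compound 1 by fluoro in place of hydrogen on an aromatic carbon, and in this assay compound 2 gives 350 nM; the resulting step is a 1.7-fold higher number from compound 1 to compound 2 (0.22 log units; within the scatter). Compound 3 `COc1cc2c(Oc3ccc(NC(=O)c4nccc(-c5ccc(F)cc5)n4)cc3F)ccnc2cc1OCCCN1CCCCC1` is built on another core, and the difference between the two cores is not broken down here. In this assay compound 3 gives 930 nM, the highest of the three numbers, beyond the scatter from both compound 1 and compound 2.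

Compound 4 `COc1cc2c(Oc3ccc(NC(=O)c4nccc(-c5ccc(F)cc5F)n4)cc3F)ccnc2cc1OCCCN1CCCCC1` has not yet been measured. It differs from compound 3 by fluoro in place of hydrogen on an aromatic carbon. Among the measured compounds shown here, this is the same kind of change as the one from compound 1 to compound 2, though the place is not the same: in compound 4 the entering fluoro sits ortho to a large group and meta to a fluoro group, whereas in compound 2 it sits para to a large group. The expected step is estimated as a 1.3-fold higher number from compound 3 to compound 4 (0.11 log units; within the scatter), an expectation resting on the earlier step of a 1.7-fold higher number from compound 1 to compound 2 (0.22 log units; within the scatter), which stayed within the scatter, with the range widened slightly for the different surroundings of the place. In this assay compound 4 is therefore expected to give about 1200 nM, estimated to fall between 500 nM and 2800 nM.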

Compound 4, half-maximal inhibitory concentration: 1120 nM
For compound 4 the middle estimate is 1.1-fold (0.03 log units) above the measured one; measured number inside the range.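

In this assay, fluoro in place of hydrogen on an aromatic carbon, here taking 4-fluorophenyl to 2,4-difluorophenyl, gives a 1.2-fold higher number from compound 3 to compound 4 (0.08 log units; within the scatter), and the two readings of this change on the two cores agree: the same change on two cores in this assay, a 1.7-fold higher number (0.22 log units; within the scatter) from compound 1 to compound 2 and a 1.2-fold higher number (0.08 log units; within the scatter) from compound 3 to compound 4, 1.4-fold (0.14 log units) apart, within the scatter of two such steps. This shows that, for these two pairs, the change stays within the scatter on both cores, and neither pair goes against that reading, so the small size of the step carries from the core of compound 1 to the core of compound 3. It does not show that the same would hold on any other core or at any other place, as the entering fluoro does not stand at the same place in the two pairs, and two pairs cannot separate the part played by the core from the part played by the place.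

The compounds shown leave open whether a chloro, a methoxy, a trifluoromethyl or a nitrile on the same aromatic carbon would give steps that agree across the two cores as these do. They also leave open how the gap between compound 2 and compound 3 divides among the places where those two compounds differ.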